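A few compounds are considered here, and "the series" means these few. Any claim that something is new, unique, unknown or untested is made for them only; others in the source may bear on it.

In an ADME assay on GES1 cells (Homo sapiens) for cytotoxicity, read by MTT assay, with a stated time of 24 h (on this read-out lower numbers stand for higher toxicity in this test and higher numbers for lower toxicity in this test), compound 1 (`O=c1[nH]cc(S(=O)(=O)Nc2ccccc2-c2cn(-c3ccccc3)nn2)c(=O)[nH]1`) gives > 100000 nM and this is a limit of the assay, not a number. Compound 2 (`O=c1[nH]cc(S(=O)(=O)Nc2ccccc2-c2cn(-c3ccccc3F)nn2)c(=O)[nH]1`) gives > 100000 nM and this too is a limit. Compound 3 (`O=c1[nH]cc(S(=O)(=O)Nc2ccccc2-c2cn(-c3cccc(F)c3)nn2)c(=O)[nH]1`) carries the entry "not toxic" (no number reported) with no number reported. Compound 1 therefore has no exact figure and stands at the limit of > 100000 nM in this assay, at which 2 of the 3 values shown sit, with nothing measured to place it more finely.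

The unmeasured compound 4 (`O=c1[nH]cc(S(=O)(=O)Nc2ccccc2-c2cn(-c3ccc(F)cc3)nn2)c(=O)[nH]1`) differs from compound 1 by one change, fluoro in place of hydrogen on an aromatic carbon and so phenyl becomes 4-fluorophenyl. Among the compounds with values here, the one measured step of this kind is a step that the two limits leave unreadable from compound 1 to compound 2 and its size cannot be read, since both ends are limits. Compound 3 also bears a fluoro on that ring and likewise has no number. The expectation for compound 4 thus rests on compound 2 at the limit of > 100000 nM in this assay and on the same limit for compound 1. No step beyond the usual scatter is expected, and no direction can be given. The expected change is a number no higher from compound 1 to compound 4 (the limit leaves the size open) and it would most likely be reported again as a limit. Compound 4 is estimated at 100000 nM with an expected range from 50000 nM to 200000 nM in this read-out.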

Compound 4, half-maximal cytotoxic concentration: "not toxic" (no number reported)
For compound 4 the study gives words and no number, and the estimate cannot be compared.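

In this assay compound 4, like compound 3, carries only the words "not toxic" and no number, so no new step can be read from compound 1 to compound 4. The compounds shown leave open whether a fluoro on the phenyl ring changes the read-out at all, as every value given stops at one limit or has no number: the limit of > 100000 nM in this assay, at which 2 of the 4 values shown sit.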